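Capping the Sulfanyl Group: From Compound 2 to Compound 3

This account rests on a few compounds, and the source may have more. Where it says the series, first, only, none or still open, it means among the compounds named here.

Compound 1 `CS(=O)(=O)N1CC(CCl)c2ccc(O)cc21` gives 20000 nM in a functional assay on CHO-AA8 cells (Cricetulus griseus) for cytotoxicity, with a stated time of 4 h; on this read-out higher numbers stand for weaker inhibition and lower numbers for stronger inhibition.
Compound 2 `CS(=O)(=O)N1CC(CCl)c2ccc(S)cc21` is recorded in this assay only as a limit, > 200000 nM.

Of the two measured compounds, only compound 1 has a definite number in this assay. As far as these compounds go, for compound 2 the read-out is a limit of the assay, not a number, so its exact position is unknown and it can only be placed at or beyond that limit. Among the compounds with values here, the one measured step, an at least 10-fold higher number from compound 1 to compound 2 (1.00 log units; beyond the scatter), therefore also rests on a limit, as the limit of > 200000 nM in this assay, at which 1 of the 2 values shown sits, records.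

Compound 3 `CSc1ccc2c(c1)N(S(C)(=O)=O)CC2CCl` has not yet been measured. It differs from compound 2 in one place: methyl in place of hydrogen on a sulfur. Within the data shown here, no measured step concerns a methyl entering on a sulfur; the only step at hand, an at least 10-fold higher number from compound 1 to compound 2 (1.00 log units; beyond the scatter), covers a different exchange and offers no guide to the size or direction of the present change. With nothing beyond the limit of compound 2 to lean on, compound 3 is expected to stay in the same region, with an at least 1.3-fold lower number from compound 2 to compound 3 (0.12 log units; that floor lies within the scatter) as the most likely outcome. The estimate for compound 3 in this assay is 150000 nM, expected to fall between 30000 nM and 600000 nM, with a substantial chance that only a limit is reported again.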

Compound 3, half-maximal inhibitory concentration: > 200000 nM
Compound 3 was reported as a limit; the forecaster's own chance of this, stated with the estimate: 55%; at least 1.3-fold (0.12 log units) between middle value and limit.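

In this assay, compound 3 joins compound 2 at a limit of the assay, so the step between these two compounds cannot be read, and the position now stands as follows: the limit of > 200000 nM in this assay, at which 2 of the 3 values shown sit.

What compound 3 adds concerns the sulfur itself. Methylsulfanyl in place of hydroxy on the aromatic carbon gives an at least 10-fold higher number from compound 1 to compound 3 (1.00 log units; beyond the scatter), so the move away from the definite number of the hydroxy compound does not require a hydrogen on the sulfur. Within these three compounds, both sulfur-bearing groups sit at the limit and only the hydroxy compound gives a measurable number.

As far as these compounds go, how far compound 2 and compound 3 lie beyond the limit stays unknown, and any real difference between sulfanyl and methylsulfanyl remains hidden from this read-out. Also open, from the compounds shown here alone, is whether an amine, or a methoxy group with oxygen where compound 3 carries sulfur, would give a definite number on this aromatic carbon, as compound 1 does with 20000 nM.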